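This account rests on a few compounds, and the source may have more. Where it says the series, first, only, none or still open, it means among the compounds named here.

Measured so far:
compound 1 `O=C(COc1ccc(C(=O)/C=C/c2ccc(Cl)cc2Cl)cc1)N[C@H]1CCOC1=O`: 34400 nM
compound 2 `O=C1OCC[C@@H]1NC(=S)SCCOc1ccccc1Cc1ccccc1`: 39500 nM

In a functional assay on MCF7 cells (Homo sapiens) for antiproliferative activity, read by MTT assay, with a stated time of 72 h (on this read-out higher numbers stand for weaker inhibition and lower numbers for stronger inhibition), compound 1 gives 34400 nM, the lower of the two numbers; compound 2 gives 39500 nM, and the gap between them lies within the scatter, so neither can be called the more potent. Compound 3 `O=C(COc1ccc(C(=O)/C=C/c2ccccc2)cc1)N[C@H]1CCOC1=O` differs from compound 1 in one place: phenyl in place of 2,4-dichlorophenyl on a double-bonded chain carbon bound to a double-bonded chain carbon. Among the compounds with values here, no step between two measured compounds is available to calibrate this change, so the expectation rests on compound 1 alone. The step of a 1.3-fold higher number from compound 1 to compound 3 (0.12 log units; within the scatter) is expected to be small, likely not beyond the scatter, with a slight lean toward a higher number. Compound 3 is estimated at 45000 nM, range 15000 nM to 130000 nM.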

Compound 3, half-maximal inhibitory concentration: > 64000 nM
Compound 3: no number, only a limit; the forecaster's own chance of this, stated with the estimate: 15%; middle value at least 1.4-fold (0.15 log units) away from the limit.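

Phenyl in place of 2,4-dichlorophenyl on a double-bonded chain carbon bound to a double-bonded chain carbon gives the first step in the series in this assay, an at least 1.8-fold higher number from compound 1 to compound 3 (0.26 log units; that floor lies within the scatter). For compound 3 there is only a limit, not a number: the limit of > 64000 nM in this assay, at which 1 of the 3 values shown sits. The floor of this step lies within the scatter, so the step is not shown to exceed it, and its upper size stays unknown.

Open, as far as these compounds go, is whether a monochlorophenyl, a methoxyphenyl or an aminophenyl in this place would give a measurable number. The role of each chlorine also stays unresolved.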